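Replacing the Aromatic Sulfonyl Group: Expected Cytotoxicity

A few compounds are considered here, and "the series" means these few. Any claim that something is new, unique, unknown or untested is made for them only; others in the source may bear on it.

Measured compounds:
Compound 1, `Cc1cc(C)c(S(=O)(=O)N2CCN(C3CN4CCC3CC4)CC2)c(C)c1`, gives > 5000 nM in an ADME assay on HCT-116 cells (Homo sapiens) for cytotoxicity, read by CellTiter-Glo, with a stated time of 72 h (a higher number here means a weaker inhibitor, a lower number a stronger inhibitor), which is a limit of the assay rather than a number.
Compound 2, `CC1CCN(C2CCN(S(=O)(=O)c3nccn3C)CC2)CC1`, gives > 10000 nM in this assay, likewise a limit.
Compound 3, `Cc1cc(C)c(S(=O)(=O)N2CCC(N3CCN(C)CC3)CC2)c(C)c1`, gives > 5000 nM in this assay, again a limit.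

Compound 2 therefore stands at the limit of > 10000 nM in this assay, at which 1 of the 3 values shown sits. The other two results sit at the limit of > 5000 nM in this assay, at which 2 of the 3 values shown sit. Among the compounds with values here, all three results are limits, so none of them places compound 2 above or below the others, and no measured step between any pair is available.

Compound 4, `CC1CCN(C2CCN(S(=O)(=O)c3cc(Cl)cc(Cl)c3)CC2)CC1`, differs from compound 2 in one place: 3,5-dichlorophenyl in place of 1-methyl-1H-imidazol-2-yl on a sulfonyl sulfur. The change is on the sulfonyl sulfur whose other neighbour is the sulfonamide nitrogen in a ring. Within the data shown here, with no measured step to lean on, the expected step of an at least 1.2-fold lower number from compound 2 to compound 4 (0.09 log units; that floor lies within the scatter) is taken as none beyond the scatter, and the result is expected to be another limit more often than a number. For compound 4 the estimated value in this assay is 8000 nM, with a range from 2000 nM to 30000 nM.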

Compound 4, half-maximal inhibitory concentration: > 5000 nM
Compound 4 ended at the assay's limit (the forecaster's own chance of this, stated with the estimate: 65%); the middle value does not contradict the limit.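

In this assay compound 4 gives > 5000 nM, a limit of the assay. Compound 2 gives > 10000 nM, also a limit, and no step can be read from compound 2 to compound 4. The compounds shown leave open how 3,5-dichlorophenyl and 1-methyl-1H-imidazol-2-yl on a sulfonyl sulfur compare.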